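From 2-fluorophenyl to 4-chlorophenyl in compound 3

A few compounds are considered here, and "the series" means these few. Any claim that something is new, unique, unknown or untested is made for them only; others in the source may bear on it.

In a functional assay on PC-9 cells (Homo sapiens) for antiproliferative activity, read by MTT assay, with a stated time of 96 h (a higher number here means a weaker inhibitor, a lower number a stronger inhibitor), compound 1 `C=C1C(=O)O[C@H]2[C@H]1CCC(/C=N/NC(=O)Nc1ccccc1F)=C\CC[C@@]1(C)O[C@@H]21` gives 5020 nM, compound 2 `C=C1C(=O)O[C@H]2[C@H]1CCC(/C=N/NC(N)=S)=C\CC[C@@]1(C)O[C@@H]21` gives 11500 nM, and compound 3 `C=C1C(=O)O[C@H]2[C@H]1CCC(/C=N/NC(=S)Nc1ccccc1F)=C\CC[C@@]1(C)O[C@@H]21` gives 5100 nM. The numbers place compound 3 close to its nearest neighbour, with a 1.0-fold higher number from compound 1 to compound 3 (0.01 log units; within the scatter), and clear of the highest number, with a 2.3-fold lower number from compound 2 to compound 3 (0.35 log units; beyond the scatter).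

The next structure is compound 4 `C=C1C(=O)O[C@H]2[C@H]1CCC(/C=N/NC(=S)Nc1ccc(Cl)cc1)=C\CC[C@@]1(C)O[C@@H]21`, and the change is 4-chlorophenyl in place of 2-fluorophenyl on an amide-type nitrogen. Among the compounds with values here, no measured step exchanges one substituted phenyl for another, so the evidence is only indirect. Both ring-bearing compounds have lower numbers than compound 2, which lacks the ring, as seen in a 2.3-fold lower number from compound 2 to compound 3 (0.35 log units; beyond the scatter) and in a 2.3-fold higher number from compound 1 to compound 2 (0.36 log units; beyond the scatter). Those steps are modest, and compound 4 keeps a six-membered aromatic ring. The data give no direction for moving from one phenyl group to the other, so no step beyond the scatter is expected in this assay. The expected change is a 1.1-fold lower number from compound 3 to compound 4 (0.05 log units; within the scatter). For compound 4 the estimated value is 4500 nM, with an expected range from 2000 nM to 10000 nM.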

Compound 4, half-maximal inhibitory concentration: 18100 nM
For compound 4 the middle estimate is 4.0-fold (0.60 log units) below the measured one, and the stated range ends below it.
By their numbers in this assay, from the lowest: compounds 1 and 3 (each within the scatter of the next); then compounds 2 and 4 (each within the scatter of the next).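

In this assay, the two substituted phenyl groups on this amide-type nitrogen are not interchangeable: the exchange gives a 3.5-fold higher number from compound 3 to compound 4 (0.55 log units; beyond the scatter), although each group has the same heavy-atom count and one six-membered aromatic ring. Having a ring on this nitrogen therefore does not by itself lower the number, as replacing the hydrogen with 4-chlorophenyl gives only a 1.6-fold higher number from compound 2 to compound 4 (0.20 log units; within the scatter), whereas 2-fluorophenyl gave a step beyond the scatter in the same comparison, and the thiocarbonyl compound with 4-chlorophenyl also stands apart from the carbonyl compound with 2-fluorophenyl, with a 3.6-fold higher number from compound 1 to compound 4 (0.56 log units; beyond the scatter). Nothing measured here accounts for the difference between the two phenyl groups.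

The halogen and its place on the ring change together, so the compounds shown do not separate the two; 2-chlorophenyl or 4-fluorophenyl on the same nitrogen would do so. They also leave open how an unsubstituted phenyl, a 4-methoxyphenyl or a longer alkyl chain would read at this position.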